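Pyridinylmethoxy in Place of Dimethylamino at Compound 3

The source may report more compounds than this note shows. Statements on the series, on what has been measured and on what is new or still open speak of the compounds shown alone.

Of the compounds shown here, three sharing one core have been measured in a functional assay on CHO cells for agonist activity at metabotropic glutamate receptor 2 (Homo sapiens), read by GTPgammaS binding; a higher number here means a larger maximal response, a lower number a smaller maximal response. Compound 1 `CCCn1ccc2cc(NCc3cccnc3)cc(Cl)c2c1=O` gives 82% in this assay. Compound 2 `CCCn1ccc2cc(OCCCc3cccnc3)cc(Cl)c2c1=O` gives 75%. Compound 3 `CCCn1ccc2cc(-c3ccc(N(C)C)nc3)cc(Cl)c2c1=O` gives 85%, the highest of the three numbers, though the gap to compound 1 and the gap to compound 2 both lie within the usual scatter, so no order among the three can be claimed.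

Compound 4 `CCCn1ccc2cc(-c3ccc(OCc4cccnc4)nc3)cc(Cl)c2c1=O` has not yet been measured. It differs from compound 3 in one place: (pyridin-3-yl)methoxy in place of dimethylamino on an aromatic carbon. The dimethylamino group leaves and the (pyridin-3-yl)methoxy group enters on the same aromatic carbon. Going by the values given here, no pair of measured compounds shows this change, so its effect can only be judged from how little the three known values differ from one another. The step of a number 5 percentage points lower from compound 3 to compound 4 (within the scatter) is expected to lie within the scatter, in either direction, with no shift beyond it. Compound 4 is estimated at 80% in this assay, between 65% and 95%.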

Compound 4, largest response reached (Emax), in percent of the reference or control that the assay uses: 120%
For compound 4 the middle estimate is 40 percentage points below the measured one; the whole stated range lies below it.
By their numbers in this assay, from the lowest: compounds 2, 1 and 3 (each within the scatter of the next); then compound 4.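

In this assay, (pyridin-3-yl)methoxy in place of dimethylamino on the aromatic carbon next to the ring nitrogen gives a number 35 percentage points higher from compound 3 to compound 4 (beyond the scatter) and so moves the maximal response well beyond the scatter. The earlier compounds shown here, whose values all lay within the scatter of one another, gave no sign that the response could shift this far, whereas this step shows that the group on this carbon can strongly raise it. Nothing at hand accounts for the rise.

As far as these compounds go, it remains open which part of the entering group carries the step: its pyridine ring, its oxygen link or its overall length. A plain methoxy group, a benzyloxy group or a longer chain ending in the same pyridine ring, each on this same carbon, would help to separate these parts.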